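The source may report more compounds than this note shows. Statements on the series, on what has been measured and on what is new or still open speak of the compounds shown alone.

The three measured compounds share a core and a urea arm, and were examined in a functional assay on PC-9 cells (Homo sapiens) for inhibition, read by MTT assay, with a stated time of 48 h, tested at 10 uM; a higher number here means more inhibition at the concentration tested (going by the name of the read-out), a lower number less inhibition. Compound 1, `COc1ccc(OC)c(Nc2cc(NC(=O)Nc3c(Cl)cccc3Cl)ncn2)c1`, gives 95% in this assay. Compound 3, `COc1ccc(Nc2cc(NC(=O)Nc3c(Cl)cccc3Cl)ncn2)cc1C`, gives 80.1%. Compound 2, `COc1cc(NC(=O)Nc2cc(Nc3cc(C)cc(F)c3)ncn2)cc(OC)c1`, gives 64.5%, the lowest of the three numbers: compound 3 lies above it by a margin beyond the scatter, and compound 1 by a still wider margin, also beyond the scatter. Compounds 1 and 3 differ from compound 2 in more than one place, so their values show only where they stand, not what any single change does.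

Compound 4, `COc1cc(NC(=O)Nc2cc(Nc3cc(F)ccc3OC)ncn2)cc(OC)c1`, keeps everything of compound 2 except the group on the nitrogen on the aromatic ring, where the change is 5-fluoro-2-methoxyphenyl in place of 3-fluoro-5-methylphenyl on a nitrogen on an aromatic ring. Among the measured compounds shown here, no step between measured compounds matches this change, so the direction has to be judged without a direct precedent. The author expects a step from compound 2 to compound 4 of a number 5.5 percentage points higher from compound 2 to compound 4 (within the scatter) in this assay, a modest rise that may well stay within the scatter. Compound 4 is therefore estimated at 70% in this assay, with a range from 50% to 88%.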

Compound 4, a percentage reported as inhibition, at one concentration (the size of the read-out at that concentration, not a potency): 59.5%
For compound 4 the middle estimate is 10.5 percentage points above the measured one, and the stated range covers the measured number.
By their numbers in this assay, from the lowest: compounds 4 and 2 (each within the scatter of the next); then compound 3; then compound 1.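

Among the compounds shown here, with the urea arm of compound 2 held fixed, this pair gives the first step that can be read at this position: in this assay, putting 5-fluoro-2-methoxyphenyl in place of 3-fluoro-5-methylphenyl on a nitrogen on an aromatic ring gives a number 5 percentage points lower from compound 2 to compound 4 (within the scatter). The assay therefore does not separate the two groups at this concentration, even though the entering group brings an oxygen and a hydrogen-bond acceptor that the leaving group lacks. Nothing at hand bears on why the two groups read alike.

On these data alone, compounds 1 and 3 differ from compound 2 and compound 4 in both the urea arm and the group on the nitrogen, so their steps to these two compounds cannot be read, and it remains open how much of their standing belongs to either part. As far as these compounds go, it also remains open how this position would read with an amine, a morpholine ring or a longer chain such as ethoxy on the aromatic ring, and whether the two groups would still read alike with the urea arm of compound 1 in place.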